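The source may hold more compounds than are shown below. What is called first, only, known or untested is meant among the compounds shown, and "the series" means these compounds.

Measured compounds:
compound 1, `CCc1cccc(C[C@H](O)/C=C/[C@H]2COC(=O)N2CCSCCCC(=O)O)c1`: 7.9 nM
compound 2, `CCCc1cccc(C[C@H](O)/C=C/[C@H]2CSC(=O)N2CCSCCCC(=O)O)c1`: 0.98 nM
compound 3, `COCc1cccc(C[C@H](O)/C=C/[C@H]2CSC(=O)N2CCSCCCC(=O)O)c1`: 1.2 nM

In an assay on CHO cells for displacement of a labelled ligand from prostaglandin E2 receptor EP4 subtype (Mus musculus), read by scintillation counting, with a stated time of 60 min (on this read-out lower numbers stand for stronger inhibition and higher numbers for weaker inhibition), compound 1 gives the highest of the three numbers; compound 3 lies nearest to it and compound 2 furthest, both beyond the scatter. Compound 2 and compound 3 sit within the scatter of each other, as the step of a 1.2-fold higher number from compound 2 to compound 3 (0.09 log units; within the scatter) shows.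

The unmeasured compound 4, `O=C(O)CCCSCCN1C(=O)OC[C@@H]1/C=C/[C@@H](O)Cc1ccccc1`, derives from compound 1 by the change (hydrogen in place of ethyl on an aromatic carbon).

Among the measured compounds shown here, none of the measured steps touches an aromatic carbon of the ring or removes a group outright; the single measured step exchanges one group for another on a saturated chain carbon and stays within the scatter. For the measured compounds named here, the expectation for compound 4 therefore rests on compound 1 alone, with no direct precedent for the loss of the ethyl. Because compound 1 gives 7.9 nM, compound 4 is expected to give a modestly higher number, estimated as the step of a 2.0-fold higher number from compound 1 to compound 4 (0.31 log units; beyond the scatter). The estimate for compound 4 is 16 nM, with a range from 5 nM to 50 nM.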

Compound 4, inhibition constant: 4.2 nM
For compound 4 the middle estimate is 3.8-fold (0.58 log units) above the measured one, outside the stated range (below it).
By their numbers in this assay, from the lowest: compounds 2 and 3 (each within the scatter of the next); then compounds 4 and 1 (each within the scatter of the next).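

In this assay, the ethyl on an aromatic carbon of the six-membered aromatic ring is not needed to hold the number in the range of compound 1: going from 3-ethylbenzyl to benzyl stays within the scatter (a 1.9-fold lower number from compound 1 to compound 4 (0.27 log units; within the scatter)). Earlier compounds showed only an exchange on a saturated chain carbon, in the core of compound 2, whereas this result concerns the aromatic carbon itself and the core of compound 1. No measurement at hand offers an explanation for this tolerance.

Open, as far as these compounds go, is whether the removal of the ethyl would read the same on the core of compound 2, where the propyl and methoxymethyl analogues, compound 2 and compound 3, stand. Also open, from the compounds shown here alone, is how an amine, a carboxylic acid or a longer chain would read on this aromatic carbon.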